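Lengthening a nitrile chain at a leukotriene receptor

The compounds below may be only part of what the source reports. "The series", "measured", "known", "first", "only" and "open" are said of these compounds alone.

Three compounds sharing one core, and differing only in the length of a chain that ends in a nitrile, have been tested in an assay on isolated protein for inhibition of leukotriene B4 receptor 1 (Homo sapiens), tested at 10 uM; a lower number here means less inhibition, a higher number more inhibition at the concentration tested (going by the name of the read-out). Compound 1, `CCc1cc(C(C)=O)c(O)cc1OCCCC(C)(C)C#N`, gives 85%. Compound 2, `CCc1cc(C(C)=O)c(O)cc1OCCCCC(C)(C)C#N`, gives 79%. Compound 3, `CCc1cc(C(C)=O)c(O)cc1OCCCCCCC(C)(C)C#N`, gives 65%. From compound 1 to compound 2 the chain gains one link, (2-cyano-2-methylpropyl in place of 1-cyano-1-methylethyl on a saturated chain carbon, three bonds along the chain from an oxygen on an aromatic ring), and the read-out moves a number 6 percentage points lower from compound 1 to compound 2 (within the scatter). The larger change 4-cyano-4-methylpentyl in place of 1-cyano-1-methylethyl on a saturated chain carbon, three bonds along the chain from an oxygen on an aromatic ring brings a number 20 percentage points lower from compound 1 to compound 3 (beyond the scatter), and the remaining pair shows a number 14 percentage points lower from compound 2 to compound 3 (beyond the scatter). Compound 3 therefore stands lowest of the three, its steps from both others beyond the scatter.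

Compound 4, `CCc1cc(C(C)=O)c(O)cc1OCCCCCCCC(C)(C)C#N`, has not yet been measured. It differs from compound 3 by 2-cyano-2-methylpropyl in place of 1-cyano-1-methylethyl on a saturated chain carbon, six bonds along the chain from an oxygen on an aromatic ring. This is the same kind of change as from compound 1 to compound 2, but not the same: there the place is three bonds along the chain from an oxygen on an aromatic ring, here it is six bonds along.

The step from compound 3 to compound 4 is expected to be a number 7 percentage points lower from compound 3 to compound 4 (within the scatter), an estimate that rests on the single-link step a number 6 percentage points lower from compound 1 to compound 2 (within the scatter) staying within the scatter while the next one, a number 14 percentage points lower from compound 2 to compound 3 (beyond the scatter), went beyond it. For compound 4 the estimated value is 58%, most likely between 46% and 70%.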

Compound 4, a percentage reported as inhibition, at one concentration (the size of the read-out at that concentration, not a potency): 66%
Compound 4: the middle estimate sits 8 percentage points below what was measured, within the range that was stated.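

In this assay the one extra link at the longer end of the series gives a number 1 percentage points higher from compound 3 to compound 4 (within the scatter), and this agrees with the same change made at the shorter end: the same change on two cores in this assay, a number 6 percentage points lower (within the scatter) from compound 1 to compound 2 and a number 1 percentage points higher (within the scatter) from compound 3 to compound 4, 7 percentage points apart, within the scatter of two such steps. The larger extension, which adds more links at once, gives a number 13 percentage points lower from compound 2 to compound 4 (beyond the scatter), and this too agrees with its earlier counterpart: the same change on two cores in this assay, a number 20 percentage points lower (beyond the scatter) from compound 1 to compound 3 and a number 13 percentage points lower (beyond the scatter) from compound 2 to compound 4, 7 percentage points apart, within the scatter of two such steps. So within these four compounds each change gave a comparable step at both chain lengths, but that rests on only two pairs of steps, all on the shared core and all read at one concentration, so it does not show that the steps are identical, that they would carry over to a different core, or how potency changes.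

The compounds shown leave open what a longer chain would give, and whether the steps would stay comparable with a carboxylic acid or an amine at the chain end in place of the nitrile. They also leave open whether the two gem-dimethyl-type methyl groups next to that nitrile matter, since every compound here carries them.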